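From Methyl to 2-Chlorophenyl: A Stability Estimate

A few compounds are considered here, and "the series" means these few. Any claim that something is new, unique, unknown or untested is made for them only; others in the source may bear on it.

In an ADME assay on S9 fraction from liver (Rattus norvegicus) for metabolic stability, read by LC-MS, using NADPH, with a stated time of 30 min (a lower number here means that less of the compound is left, a higher number that more of the compound is left), compound 1 `CCCCCCCCc1ccc(OCC(=O)Cn2nnc(C(=O)OC)n2)cc1` reads < 5%, which is a limit of the assay rather than a number. Within the data shown here, compound 2 `CCCCCCCCc1ccc(OCC(=O)Cn2nnnc2C)cc1` gives 32%, the only true number so far. Compound 3 `CCCCCCCCc1ccc(OCC(=O)Cn2nnnc2-c2ccccc2Cl)cc1` carries 2-chlorophenyl in place of methyl on an aromatic carbon. Among the measured compounds shown here, the one measured step, a number at least 27 percentage points higher from compound 1 to compound 2 (beyond the scatter), was large but exchanged a different group and starts from a limit, so it sets no direction here. The expected step, a number 5 percentage points lower from compound 2 to compound 3 (within the scatter), is estimated to stay within the scatter. Compound 3 is expected at 27%, within a range of 10% to 45%.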

Compound 3, percent of the compound remaining: 42%
For compound 3 the middle estimate is 15 percentage points below the measured one; the measured number falls inside the stated range.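

In this assay, 2-chlorophenyl in place of methyl gives a number 10 percentage points higher from compound 2 to compound 3 (within the scatter). This aromatic carbon between two ring nitrogen atoms therefore carries 7 heavy atoms instead of 1 with no difference beyond the scatter, something the earlier step, which exchanged a different group, could not show. Compound 1 is a limit of the assay, not a number: the limit of < 5% in this assay, at which 1 of the 3 values shown sits.

Whether the chlorine matters stays open, since a plain phenyl is not among the compounds shown. So does how an amine or a carboxylic acid at this carbon would read.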